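The source may report more compounds than this note shows. Statements on the series, on what has been measured and on what is new or still open speak of the compounds shown alone.

Compound 1 `CC1=CCC[C@](C)(CC/C(C)=C/CC2=C(O)C(=O)C=C(N[C@@H](C(=O)O)[C@@H](C)O)C2=O)[C@@H]1C`; in an ADME assay on L1210 cells (Mus musculus) for cytotoxicity, with a stated time of 48 h (on this read-out higher numbers stand for weaker inhibition and lower numbers for stronger inhibition), compound 1 gives > 10 ug/mL, which is a limit of the assay.
Compound 2 `C=C1[C@H](C)CCC[C@]1(C)CC/C(C)=C/CC1=C(O)C(=O)C=C(N[C@@H](C(=O)O)[C@@H](C)O)C1=O`; compound 2 gives > 10 ug/mL, also a limit.
Compound 3 `C=C1[C@H](C)CCC[C@]1(C)CC/C(C)=C/CC1=C(O)C(=O)C=C(N[C@H](C(=O)O)C(C)C)C1=O`; compound 3 gives 4.4 ug/mL.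

Compound 1 thus stands at the limit of > 10 ug/mL in this assay, at which 2 of the 3 values shown sit, with no number of its own. Compound 4 `CC1=CCC[C@](C)(CC/C(C)=C/CC2=C(O)C(=O)C=C(N[C@H](C(=O)O)[C@H](C)O)C2=O)[C@@H]1C` keeps every atom and bond of compound 1 and differs only in configuration: the two compounds have the same atoms and bonds and differ only in configuration as drawn: 2 of 5 stereo elements differ; a stereocentre at a saturated chain carbon is drawn R in compound 1 and S in compound 4; a stereocentre at a saturated chain carbon is drawn R in compound 1 and S in compound 4. Neither measured step concerns a change of configuration. The step that the two limits leave unreadable from compound 1 to compound 2 exchanges one ring group for another, and the step of an at least 2.2-fold lower number from compound 2 to compound 3 (0.35 log units; beyond the scatter) replaces the side chain on the amine nitrogen. For the measured compounds named here, no measured step therefore speaks to the change at hand, and compound 4 is expected to stay near compound 1, a step that the limit leaves unreadable from compound 1 to compound 4 with no clear direction. The estimate for compound 4 is 15 ug/mL, between 5 ug/mL and 50 ug/mL.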

Compound 4, half-maximal inhibitory concentration: > 10 ug/mL
Compound 4 was reported as a limit; the forecaster's own chance of this, stated with the estimate: 70%; the middle value lies beyond the limit too.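

Compound 4, like compound 1, gives only a limit in this assay, so the step between them cannot be read: the limit of > 10 ug/mL in this assay, at which 3 of the 4 values shown sit. Going by these compounds, whether this change of configuration alters cytotoxicity at all stays open: neither compound has a number of its own.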